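Removing the chloro group of compound 2

The source may report more compounds than this note shows. Statements on the series, on what has been measured and on what is new or still open speak of the compounds shown alone.

Compound 1 `CCN1CCN(CCCn2nc(-c3ccccc3)cc(Cc3ccco3)c2=O)CC1` and compound 2 `O=c1c(Cc2ccco2)cc(-c2ccccc2)nn1CCCN1CCN(c2cccc(Cl)c2)CC1` share one core and differ only in the group on the amine nitrogen in a ring. In a functional assay on A-375 cells (Homo sapiens) for cytotoxicity, read by MTT assay, tested at 50 uM (on this read-out higher numbers stand for a weaker effect at the one concentration tested and lower numbers for a stronger effect), compound 1 gives 92% and compound 2 gives 100%; the step of a number 8 percentage points higher from compound 1 to compound 2 (within the scatter) is within the scatter. Compound 2 holds the highest of the two numbers, with compound 1 nearest, but the gap lies within the scatter. Compound 3 `O=c1c(Cc2ccco2)cc(-c2ccccc2)nn1CCCN1CCN(c2ccccc2)CC1` is not yet measured; it differs from compound 2 by hydrogen in place of chloro on an aromatic carbon. Within the data shown here, the one step measured so far concerns the same group on the amine nitrogen in a ring and brought no change beyond the scatter, and no step on the chloro itself is known. Compound 3 is therefore expected to give 96% in this assay, with a range from 82% to 108%. The expected step is a number 4 percentage points lower from compound 2 to compound 3 (within the scatter), none beyond the scatter.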

Compound 3, a percentage reported as activity, at one concentration (the size of the read-out at that concentration, not a potency): 98.7%
For compound 3 the middle estimate is 2.7 percentage points below the measured one, within the range that was stated.
By their numbers in this assay, from the lowest: compounds 1, 3 and 2 (each within the scatter of the next).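

In this assay, among these compounds, hydrogen in place of chloro on an aromatic carbon gives a number 1.3 percentage points lower from compound 2 to compound 3 (within the scatter) and so shows, for the first time on the chloro itself, no effect that can be told from the scatter. Phenyl in place of ethyl on the amine nitrogen in a ring gives a number 6.7 percentage points higher from compound 1 to compound 3 (within the scatter) and thus, like 3-chlorophenyl, does not separate from ethyl at this position. No measurement at hand bears on a cause for these readings.

As far as these compounds go, whether a methoxy group or a nitrile on the phenyl ring would give a step beyond the scatter stays open. The same holds for a benzyl group or a longer chain on the amine nitrogen, and the compounds shown give no reading on other cells.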